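Furan-2-yl hydrazone in the hydroxybenzofuran series

The source may report more compounds than this note shows. Statements on the series, on what has been measured and on what is new or still open speak of the compounds shown alone.

Compound 3 `Cc1c(C(=O)N/N=C\c2cc(O)ccc2O)oc2cccc(O)c12` stands highest in a functional assay on PC-3 cells (Homo sapiens) for inhibition (a higher number here means a weaker inhibitor, a lower number a stronger inhibitor), at 95500 nM; compound 1 `Cc1c(C(=O)N/N=C\c2ccccc2O)oc2cccc(O)c12` gives 8350 nM and compound 2 `Cc1c(C(=O)N/N=C\c2cccc(O)c2O)oc2cccc(O)c12` gives 12200 nM. The move to compound 4 `Cc1c(C(=O)N/N=C\c2ccco2)oc2cccc(O)c12` is furan-2-yl in place of 2,5-dihydroxyphenyl on a carbon with a double bond to nitrogen. Among the compounds with values here, no measured step exchanges the whole ring; the nearest ones bear on the hydroxy pattern only: an 11-fold higher number from compound 1 to compound 3 (1.06 log units; beyond the scatter) and a 7.8-fold higher number from compound 2 to compound 3 (0.89 log units; beyond the scatter), both beyond the scatter, while a 1.5-fold higher number from compound 1 to compound 2 (0.16 log units; within the scatter) stays within it. Within the data shown here, removing the 2,5-dihydroxyphenyl therefore removes the grouping that went with the weakest number, but the furan-2-yl has no precedent here, so a modest downward step is expected, a 4.8-fold lower number from compound 3 to compound 4 (0.68 log units; beyond the scatter). Compound 4 is estimated at 20000 nM, with a range of 5000 nM to 80000 nM.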

Compound 4, half-maximal inhibitory concentration: >= 40000 nM
Compound 4 was reported as a limit; the forecaster's own chance of this, stated with the estimate: 10%; middle value at least 2.0-fold (0.30 log units) away from the limit.
By their numbers in this assay, from the lowest: compounds 1 and 2 (each within the scatter of the next); then compound 3.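

In this assay compound 4 gives >= 40000 nM, which is a limit of the assay and not a number. Furan-2-yl in place of 2-hydroxyphenyl gives an at least 4.7-fold higher number from compound 1 to compound 4 (0.68 log units; beyond the scatter), and furan-2-yl in place of 2,3-dihydroxyphenyl gives an at least 3.2-fold higher number from compound 2 to compound 4 (0.51 log units; beyond the scatter), so on this carbon the ring exchange costs activity against both of these compounds. The step from compound 3 cannot be read, so furan-2-yl and 2,5-dihydroxyphenyl remain unranked.

Still open, on these data alone, is whether the loss follows the missing hydroxy groups or the five-membered ring itself. Unsubstituted phenyl on this carbon would separate the two.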